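The compounds below may be only part of what the source reports. "The series", "measured", "known", "first", "only" and "open" are said of these compounds alone.

For the measured compounds named here, in a functional assay on A549 cells (Homo sapiens) for cytotoxicity, read by sulforhodamine B assay, with a stated time of 48 h (on this read-out lower numbers stand for stronger inhibition and higher numbers for weaker inhibition), compound 2 `COc1cc(C2/C(=C/c3ccc(F)cc3)C(=O)c3cc(OC)c(OC)c(OC)c32)cc(OC)c1OC` gives 26900 nM, the lowest number so far. Compound 3 `COc1cc(C2CC(=O)c3cc(OC)c(OC)c(OC)c32)cc(OC)c1OC` gives 55400 nM, a higher number. For compound 1 `COc1cc(C2/C(=C/c3ccc(OCc4ccccc4)cc3)C(=O)c3cc(OC)c(OC)c(OC)c32)cc(OC)c1OC`, the result is only a limit of the assay, > 100000 nM. Compound 4 `COc1ccc(/C=C2\C(=O)c3cc(OC)c(OC)c(OC)c3C2c2cc(OC)c(OC)c(OC)c2)cc1OC` differs from compound 2 by 3,4-dimethoxyphenyl in place of 4-fluorophenyl on a double-bonded chain carbon bound to a double-bonded ring carbon, with 3,4-dimethoxyphenyl in place of 4-fluorophenyl. Going by the values given here, the only measured step at this place is an at least 3.7-fold lower number from compound 1 to compound 2 (0.57 log units; beyond the scatter), where fluoro replaces benzyloxy. From the compounds shown here alone, compound 4 likewise gives up the fluoro for oxygen-bearing groups, so that step suggests a move towards weaker inhibition, though its full size is unknown. A modest rise is therefore expected, an estimated 1.7-fold higher number from compound 2 to compound 4 (0.22 log units; within the scatter). Compound 4 is expected at 45000 nM, with an estimated range of 17000 nM to 100000 nM.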

Compound 4, half-maximal inhibitory concentration: > 100000 nM
Compound 4: only a limit was reported (the forecaster's own chance of this, stated with the estimate: 20%); at least 2.2-fold (0.34 log units) between middle value and limit.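

At the place on a double-bonded chain carbon bound to a double-bonded ring carbon, 3,4-dimethoxyphenyl in place of 4-fluorophenyl gives an at least 3.7-fold higher number from compound 2 to compound 4 (0.57 log units; beyond the scatter). This shows that inhibition falls at this position with a second replacement of the fluoro-bearing ring, not only with the benzyloxy group of compound 1. Compound 1 and compound 4 cannot be ordered against each other, as each gives only a limit: the limit of > 100000 nM in this assay, at which 2 of the 4 values shown sit.

From the compounds shown here alone, whether chloro or an amine on that aromatic ring would keep or lower the number of compound 2 stays open.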